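Allyl to Isobutyl on the Amine of an Enaminone

The source may report more compounds than this note shows. Statements on the series, on what has been measured and on what is new or still open speak of the compounds shown alone.

Measured so far:
- compound 1, `CCC(C)NC(=C\C(=O)/C=C/c1ccc(OC(C)=O)c(OC)c1)/C=C/c1ccc(OC(C)=O)c(OC)c1`: > 25000 nM
- compound 2, `C=CCNC(=C\C(=O)/C=C/c1ccc(O)c(OC)c1)/C=C/c1ccc(O)c(OC)c1`: 7400 nM

Two compounds share a core built from two phenyl rings joined through a chain carrying a carbonyl and an amine. In a functional assay on CHO-K1 cells (Cricetulus griseus) for inhibition, read by MTT assay, with a stated time of 72 h (a higher number here means a weaker inhibitor, a lower number a stronger inhibitor), compound 1 gives > 25000 nM, which is a limit of the assay and not a measured number. For the measured compounds named here, compound 2, with free phenols and an allylamino group, gives 7400 nM in this assay, the only actual number here, with compound 1 sitting at the limit of > 25000 nM in this assay, at which 1 of the 2 values shown sits.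

Compound 3, `COc1cc(/C=C/C(=O)/C=C(/C=C/c2ccc(O)c(OC)c2)NCC(C)C)ccc1O`, differs from compound 2 by isopropyl in place of vinyl on a saturated chain carbon bound to an amine nitrogen. Going by the values given here, no step between measured compounds is available to calibrate such a change. Isopropyl in place of vinyl is a small alteration of a chain on the amine, so the expected step from compound 2 to compound 3 is a 1.1-fold higher number from compound 2 to compound 3 (0.03 log units; within the scatter), none beyond the usual scatter. Compound 3 is therefore estimated at 8000 nM, with a range from 3000 nM to 22000 nM.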

Compound 3, half-maximal inhibitory concentration: > 25000 nM
Compound 3: no number, only a limit; the forecaster's own chance of this, stated with the estimate: 15%; middle value at least 3.1-fold (0.49 log units) away from the limit.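

For the compounds shown here, this is the first step that can be read at this position, and it shows that the chain on the amine does matter here. In this assay, going from allylamino to isobutylamino gives an at least 3.3-fold higher number from compound 2 to compound 3 (0.52 log units; beyond the scatter). Compound 3 gives > 25000 nM, which is a limit of the assay and not a number, and that limit is common in this small set: the limit of > 25000 nM in this assay, at which 2 of the 3 values shown sit.

The compounds shown leave open whether the weaker result goes with losing the double bond or with gaining the extra carbon, as both change together in this one step. A propyl group on the amine would keep the double bond absent without adding that carbon, and so would pull the two changes apart.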